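Notes on compound 4 in the adenosine series

The compounds below may be only part of what the source reports. "The series", "measured", "known", "first", "only" and "open" are said of these compounds alone.

Compound 3 `O[C@@H]1[C@@H](CO/C(S)=N/C2CCCCC2)OC(n2cnc3c(NC4CCOC4)ncnc32)[C@@H]1O` shows the highest number of the three measured: in an assay on DDT1 cells (Cricetulus griseus) for binding affinity to adenosine receptor A1 (Homo sapiens), read by radioligand binding (a lower number here means a stronger inhibitor, a higher number a weaker inhibitor), compound 3 gives 253 nM, against compound 2 `CC(C)/N=C(\S)OC[C@H]1OC(n2cnc3c(NC4CCOC4)ncnc32)[C@H](O)[C@@H]1O` with 36 nM and compound 1 `CC(C)NC(=O)OC[C@H]1OC(n2cnc3c(NC4CCOC4)ncnc32)[C@H](O)[C@@H]1O` with 78 nM. Compound 4 `CN(C)C(=S)OC[C@H]1OC(n2cnc3c(NC4CCOC4)ncnc32)[C@H](O)[C@@H]1O` differs from compound 3 by a group of 5 heavy atoms (3 carbon, 1 nitrogen, 1 sulfur; no ring) in place of a group of 9 heavy atoms (7 carbon, 1 nitrogen, 1 sulfur; one six-membered non-aromatic ring of carbon only), on an oxygen on a saturated carbon. The step that bears on this is a 7.0-fold higher number from compound 2 to compound 3 (0.85 log units; beyond the scatter), where the larger group raised the number; a 3.2-fold higher number from compound 1 to compound 3 (0.51 log units; beyond the scatter) points the same way, while a 2.2-fold lower number from compound 1 to compound 2 (0.34 log units; beyond the scatter) is a separate exchange. Removing the six-membered ring in favour of the smaller group is therefore expected to give a downward step in this assay, on the order of a 4.2-fold lower number from compound 3 to compound 4 (0.62 log units; beyond the scatter). Compound 4 is expected at 60 nM, within 20 nM to 200 nM.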

Compound 4, inhibition constant: 205 nM
Beside the measured number, compound 4's estimate is 3.4-fold (0.53 log units) below it; the measured number lies above the stated range.
By their numbers in this assay, from the lowest: compound 2; then compound 1; then compounds 4 and 3 (each within the scatter of the next).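

In this assay the exchange on this oxygen gives a 1.2-fold lower number from compound 3 to compound 4 (0.09 log units; within the scatter) and so loss of the six-membered ring does not by itself set the number here. The group of 5 heavy atoms, with 0 hydrogen-bond donors, also falls short of the isopropyl compounds, as a 5.7-fold higher number from compound 2 to compound 4 (0.76 log units; beyond the scatter) and a 2.6-fold higher number from compound 1 to compound 4 (0.42 log units; beyond the scatter) show, so a smaller group alone is not enough. No measured evidence explains this result. Still open, from the compounds shown here alone, is whether a single methyl or a tert-butyl on the nitrogen of this group would follow compound 2 or compound 4.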